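Compound 3 to Compound 4: One Group Exchanged

The source may report more compounds than this note shows. Statements on the series, on what has been measured and on what is new or still open speak of the compounds shown alone.

Measured in a physicochemical assay for lipophilicity, using the shake flask method, in phosphate buffer, measured as octanol-water partition, with a stated time of 30 min, at pH 7.4; a higher number here means a more lipophilic compound, a lower number a more polar compound:
- compound 1 `O=C(Nc1ccccc1)c1cnc(NCc2c(F)ccc3c2CCO3)n2cnnc12`: 4.1
- compound 2 `COCCC(=O)Nc1cnc(NCc2c(F)ccc3c2CCO3)n2cnnc12`: 1.4
- compound 3 `CC1(C)CC(=O)N(c2cnc(NCc3c(F)ccc4c3CCO4)n3cnnc23)C1`: 2

With 2, compound 3 holds the middle place of these three. Its nearer neighbour lies below it, as the measured gap shows: a number 0.60 log units higher from compound 2 to compound 3 (beyond the scatter). The far end of the series is much further away: a number 2.10 log units lower from compound 1 to compound 3 (beyond the scatter).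

The next compound to consider is compound 4 `CN(c1ccn(C)n1)c1cnc(NCc2c(F)ccc3c2CCO3)n2cnnc12`, which keeps the shared core and exchanges one group on an aromatic carbon: methyl(1-methyl-1H-pyrazol-3-yl)amino in place of 4,4-dimethyl-2-oxopyrrolidin-1-yl on an aromatic carbon. Within the data shown here, no measured compound carries the entering group, so the data offer no direct reading of it.

Two large steps, a number 2.70 log units lower from compound 1 to compound 2 (beyond the scatter) and a number 2.10 log units lower from compound 1 to compound 3 (beyond the scatter), both start from the phenylcarbamoyl group, which neither compound 3 nor compound 4 carries. They are therefore a poor guide here. The closest guide is the modest a number 0.60 log units higher from compound 2 to compound 3 (beyond the scatter), an exchange between two groups that are both absent from compound 1. On that basis, only a small upward move in this assay is expected, with no shift beyond the scatter. The expected step is a number 0.20 log units higher from compound 3 to compound 4 (within the scatter). For compound 4 the estimated value is 2.2, with an expected range from 1.6 to 2.9.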

Compound 4, distribution coefficient: 1.8
The estimate for compound 4 lay 0.40 log units above the measured number, within the range that was stated.
By their numbers in this assay, from the lowest: compound 2; then compounds 4 and 3 (each within the scatter of the next); then compound 1.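

In this assay, the exchange on this aromatic carbon gives a number 0.20 log units lower from compound 3 to compound 4 (within the scatter) even though the two groups differ in kind: the leaving group is a five-membered non-aromatic ring with 1 hetero atom and 1 hydrogen-bond acceptor, while the entering group is a five-membered aromatic ring with 2 hetero atoms, and it brings 3 hydrogen-bond acceptors. Both groups have 8 heavy atoms, and this pair shows that a change in ring type and acceptor count need not produce a step beyond the scatter at this position. The new group can also be set against the other two, with a number 0.40 log units higher from compound 2 to compound 4 (beyond the scatter) as a modest step from the ((2-methoxyethyl)carbonyl)amino group and a number 2.30 log units lower from compound 1 to compound 4 (beyond the scatter) as a large step from the phenylcarbamoyl group, but no measurement offered here accounts for any of these steps.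

The compounds shown leave open how a simple amine or a carboxylic acid on this aromatic carbon would compare with these groups. They also leave open where a longer chain on the pyrazole ring, in place of its methyl, would fall.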